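The source may report more compounds than this note shows. Statements on the series, on what has been measured and on what is new or still open speak of the compounds shown alone.

Measured so far in a functional assay on HEK293 cells for agonist activity at G-protein coupled receptor 39 (Homo sapiens), read by scintillation proximity assay and inositol phosphate accumulation, with a stated time of 75 min; on this read-out higher numbers stand for an effect only at larger amounts of compound and lower numbers for an effect already at smaller amounts:
compound 1 `Cc1nn(-c2ncnc3nc[nH]c23)c2c1C(OCC(=O)c1ccc(F)cc1)CC(=O)N2`, 973 nM
compound 2 `Cc1nn(-c2ncnc3nc[nH]c23)c2c1C(OC1CCCC1)CC(=O)N2`, 62 nM

For the measured compounds named here, compound 2 holds the lowest of the two numbers in this assay, with compound 1 the only neighbour. The single shown step, a 16-fold lower number from compound 1 to compound 2 (1.20 log units; beyond the scatter), pairs cyclopentyl against ((4-fluorophenyl)carbonyl)methyl on the same oxygen.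

Compound 3 `Cc1cc(C)n(CCOC2CC(=O)Nc3c2c(C)nn3-c2ncnc3nc[nH]c23)n1` is not yet measured. Its difference from compound 2: 2-(3,5-dimethyl-1H-pyrazol-1-yl)ethyl in place of cyclopentyl on an oxygen on a saturated carbon. Going by the values given here, the group entering is again a chain-linked substituent carrying a ring, closer in kind to the group of compound 1 than to cyclopentyl, so the one measured step bears on it directly. That step was large and ran toward the lower number when cyclopentyl entered; replacing cyclopentyl is therefore expected to move the number upward again, though the pyrazole chain is not the same group as in compound 1, so a smaller move is assumed. For compound 3 the expected step is a 5.6-fold higher number from compound 2 to compound 3 (0.75 log units; beyond the scatter). Compound 3 is estimated at 350 nM, within 100 nM to 1500 nM.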

Compound 3, half-maximal effective concentration: 2000 nM
Compound 3: middle estimate off by 5.7-fold (0.76 log units), on the low side; measured number above the stated range.
By their numbers in this assay, from the lowest: compound 2; then compound 1; then compound 3.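

Within this assay, the oxygen substituent on the saturated carbon again moves the number strongly, now upward, with a 32-fold higher number from compound 2 to compound 3 (1.51 log units; beyond the scatter), as 2-(3,5-dimethyl-1H-pyrazol-1-yl)ethyl enters for cyclopentyl. The two chain-linked groups also differ from each other, with a 2.1-fold higher number from compound 1 to compound 3 (0.31 log units; beyond the scatter), so the pyrazole chain stands highest of the three and the ketone-bearing aryl chain of compound 1 stands in the middle. Among these three compounds, the lowest number belongs to the one with a carbocycle directly on the oxygen, and neither chain-linked compound reaches it, but no measurement on hand bears on the reason for these steps.

Open, as far as these compounds go, is whether the low number of compound 2 follows the ring on the oxygen or the missing chain, which a cyclohexyl, a 2-cyclopentylethyl or a plain ethyl group would help separate. Also open, from the compounds shown here alone, is how an amine or a carboxylic acid at the end of the chain would compare.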